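The compounds below may be only part of what the source reports. "The series", "measured", "known", "first", "only" and "open" are said of these compounds alone.

Measured so far, in an assay on RAW264.7 cells for antagonist activity at Toll-like receptor 2 (Mus musculus), read by Griess assay, with a stated time of 24 h; on this read-out higher numbers stand for weaker inhibition and lower numbers for stronger inhibition:

compound 1 `C=CCCCSC[C@H](NC(=O)c1cc(O)c(O)c(O)c1)C(=O)OC` gives 39200 nM
compound 2 `COC(=O)[C@H](CSCc1ccccc1)NC(=O)c1cc(O)c(O)c(O)c1` gives 60700 nM

For the measured compounds named here, of these two numbers, compound 2 stands at the higher one; its only neighbour is compound 1, and the step of a 1.5-fold higher number from compound 1 to compound 2 (0.19 log units; within the scatter) is small enough to lie within the ordinary scatter of repeated measurements. That single step swaps a phenyl for a but-3-en-1-yl on a saturated chain carbon bound to a sulfur, so the two compounds cannot be told apart on this read-out.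

Compound 3 `COC(=O)[C@H](CSCc1ccc(F)cc1)NC(=O)c1cc(O)c(O)c(O)c1` is the next compound. It keeps everything in compound 2 and differs only by fluoro in place of hydrogen on an aromatic carbon. Going by the values given here, no measured step touches the aromatic ring itself, so there is nothing in the data that points to a change in either direction. The expectation for compound 3 is therefore a step of about a 1.0-fold lower number from compound 2 to compound 3 (0.01 log units; within the scatter), that is, a number close to compound 2, with an estimated value of 60000 nM and a range from 25000 nM to 150000 nM.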

Compound 3, half-maximal inhibitory concentration: 50200 nM
The estimate for compound 3 lay 1.2-fold (0.08 log units) above the measured number; low and high end bracket the measured number.
By their numbers in this assay, from the lowest: compounds 1, 3 and 2 (each within the scatter of the next).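

In this assay, for the compounds shown here, this is the first change made on the aromatic ring itself: fluoro in place of hydrogen, para to a large group, gives a 1.2-fold lower number from compound 2 to compound 3 (0.08 log units; within the scatter), so this single-atom swap cannot be told apart from no change at all. Set against the but-3-en-1-yl group, the 4-fluorophenyl group gives a 1.3-fold higher number from compound 1 to compound 3 (0.11 log units; within the scatter), which leaves all three compounds indistinguishable on this read-out. Nothing available offers an explanation for this result.

From the compounds shown here alone, it remains open whether a different group at this ring position, such as a methoxy or an amine, would move the number beyond the scatter. Also open, going by these compounds, is whether a longer chain on the sulfur, or a carboxylic acid in place of the methyl ester, would separate these compounds.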